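Working notes on a four-compound cytotoxicity series

A few compounds are considered here, and "the series" means these few. Any claim that something is new, unique, unknown or untested is made for them only; others in the source may bear on it.

Measured so far:
compound 1 `Cc1c(O)ccc2c1[C@H](Cn1cc(-c3ccc(Cl)cc3)nn1)[C@@]13CC(=O)[C@@](C)(CC[C@@H]21)C3` gives > 20000 nM
compound 2 `Cc1ccc(S(=O)(=O)Oc2ccc3c(c2C)[C@H](Cn2cc(-c4ccc(Cl)cc4)nn2)[C@@]24CC(=O)[C@@](C)(CC[C@@H]32)C4)cc1` gives > 20000 nM
compound 3 `Cc1ccc(-c2cn(C[C@H]3c4c(ccc(O)c4C)[C@@H]4CC[C@@]5(C)C[C@]43CC5=O)nn2)cc1` gives > 20000 nM

In a functional assay on MCF7 cells (Homo sapiens) for cytotoxicity, read by MTT assay, with a stated time of 4 days (a lower number here means a stronger inhibitor, a higher number a weaker inhibitor), compound 1 gives > 20000 nM, which is a limit of the assay and not a number. Compound 2 differs from compound 1 by (4-methylphenyl)sulfonyl in place of hydrogen on an oxygen on an aromatic ring. In this assay compound 2 gives > 20000 nM, again a limit. The step that the two limits leave unreadable from compound 1 to compound 2 therefore cannot be sized. Compound 3 differs from compound 1 by methyl in place of chloro on an aromatic carbon. In this assay compound 3 gives > 20000 nM, likewise a limit. The step that the two limits leave unreadable from compound 1 to compound 3 is equally unreadable. All three results rest at the limit of > 20000 nM in this assay, at which 3 of the 3 values shown sit, so no ordering among compound 1, compound 2 and compound 3 can be drawn.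

Compound 4 `Cc1ccc(-c2cn(C[C@H]3c4c(ccc(OS(=O)(=O)c5ccc(C)cc5)c4C)[C@@H]4CC[C@@]5(C)C[C@]43CC5=O)nn2)cc1` has not yet been measured in this assay. It differs from compound 3 by (4-methylphenyl)sulfonyl in place of hydrogen on an oxygen on an aromatic ring. Among the measured compounds shown here, this is the same change as the one from compound 1 to compound 2, and the two place descriptions agree word for word; the two cores differ from one another by methyl in place of chloro on an aromatic carbon. Beside the earlier step that the two limits leave unreadable from compound 1 to compound 2, the step that the limit leaves unreadable from compound 3 to compound 4 is the one expected here, an expectation that rests on compound 2 sitting at > 20000 nM and compound 3 sitting at > 20000 nM, both limits. Compound 4 is estimated at 40000 nM, within 12000 nM to 150000 nM, most probably reported only as a limit once more.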

Compound 4, half-maximal inhibitory concentration: > 20000 nM
Compound 4 ended at the assay's limit; the forecaster's own chance of this, stated with the estimate: 85%; the middle value does not contradict the limit.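

In this assay compound 4 gives > 20000 nM, a limit and not a number. Neither the step to compound 4 from compound 3 nor the one from compound 2 can therefore be read: the limit of > 20000 nM in this assay, at which 4 of the 4 values shown sit.

The compounds shown leave open how far compound 1, compound 2, compound 3 or compound 4 lies from that limit, and whether either change alters cytotoxicity at all.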